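The source may hold more compounds than are shown below. What is called first, only, known or untested is meant among the compounds shown, and "the series" means these compounds.

Measured in a functional assay on L1210 cells (Mus musculus) for inhibition; on this read-out higher numbers stand for weaker inhibition and lower numbers for stronger inhibition:

- compound 1 `Nc1nc(O)c2ncn(C/C=C/CO)c2n1`: 200000 nM
- compound 2 `Nc1ccn(C/C=C\CCl)c(=O)n1`: 10000 nM
- compound 3 `Nc1ncnc2c1ncn2C=C=CCCl`: 45000 nM

Among these three compounds, compound 1 gives the highest number and so the weakest inhibition. Compound 3 is its nearest neighbour and compound 2 its furthest, and both gaps lie beyond the usual scatter of this assay.

The next compound to be examined is compound 4 `Nc1nc(O)c2ncn(C3C=CCO3)c2n1`, which keeps the core of compound 1 and changes only the group on an aromatic nitrogen of a five-membered aromatic ring with 2 nitrogen. The 4-hydroxybut-2-en-1-yl group leaves, and a group with one five-membered non-aromatic ring with 1 hetero atom enters: a group of 5 heavy atoms (4 carbon, 1 oxygen; one five-membered non-aromatic ring with 1 hetero atom) in place of a group of 5 heavy atoms (4 carbon, 1 oxygen; no ring), on an aromatic nitrogen.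

Among the measured compounds shown here, no two measured compounds differ in one place only, so the data offer no direct precedent for this change. With compound 1 at 200000 nM, the top of the measured numbers, a small step toward a lower number is expected, and a step within the scatter would be no surprise. The estimated change is a 1.7-fold lower number from compound 1 to compound 4 (0.22 log units; within the scatter). For compound 4 the estimated value is 120000 nM, with an expected range of 40000 nM to 300000 nM.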

Compound 4, half-maximal inhibitory concentration: > 350000 nM
Compound 4 ended at the assay's limit; the forecaster's own chance of this, stated with the estimate: 25%; at least 2.9-fold (0.46 log units) between middle value and limit.
By their numbers in this assay, from the lowest: compound 2; then compound 3; then compound 1. At a limit, above all of these: compound 4.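

Compound 1 and compound 4 are the only pair among the compounds shown that differ in one place, so this position on an aromatic nitrogen now has a direct comparison in this assay. Compound 4 gives > 350000 nM, which is a limit of the assay and not a number: the limit of > 350000 nM in this assay, at which 1 of the 4 values shown sits. The step reads an at least 1.7-fold higher number from compound 1 to compound 4 (0.24 log units; that floor lies within the scatter), so on this core, replacing the open 4-hydroxybut-2-en-1-yl group with a group of equal heavy-atom count that carries a five-membered non-aromatic ring brought no lower number.

As far as these compounds go, with only a floor for this step, its true size stays unknown, and this single pair cannot separate the effect of the ring from that of losing the hydrogen-bond donor, which the leaving group has and the entering group lacks. From the compounds shown here alone, how a longer chain, or an open chain ending in an amine or a carboxylic acid, would fare on this nitrogen of the core of compound 1 remains open.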